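The source may hold more compounds than are shown below. What is called first, only, known or untested is meant among the compounds shown, and "the series" means these compounds.

Compound 1, `FC(F)(F)c1ccc(Nc2cc3[nH]c(-c4cccc(C(F)(F)F)c4)nc3cn2)nc1`. In a physicochemical assay for solubility, using the shake flask method, measured as kinetic solubility, with a stated time of 20 h, at pH 2 (on this read-out lower numbers stand for lower solubility and higher numbers for higher solubility), compound 1 gives < 5000 nM, which is a limit of the measurement.
Compound 2, `O=C(O)c1ccc(Nc2cc3[nH]c(-c4cccc(C(F)(F)F)c4)nc3cn2)nc1`. In this assay compound 2 gives < 5000 nM, again only a limit.
Compound 3, `NC(=O)c1ccc(Nc2cc3[nH]c(-c4cccc(C(F)(F)F)c4)nc3cn2)nc1`. In this assay compound 3 gives < 5000 nM, also a limit.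

Compound 3 thus stands at the same limit as the other two members of the series (the limit of < 5000 nM in this assay, at which 3 of the 3 values shown sit); no ordering among the three is readable. Accordingly the steps a step that the two limits leave unreadable from compound 1 to compound 2, a step that the two limits leave unreadable from compound 1 to compound 3 and a step that the two limits leave unreadable from compound 2 to compound 3 give no size.

Compound 4, `FC(F)(F)c1cccc(-c2nc3cnc(Nc4ccc(-c5nnn[nH]5)cn4)cc3[nH]2)c1`, differs from compound 3 in one place: 1H-tetrazol-5-yl in place of carbamoyl on an aromatic carbon. Among the measured compounds shown here, none of the measured steps yields a readable size for a change of this kind, so no shift beyond the scatter can be argued either way. Compound 4 is therefore expected near the limit at 3000 nM, range 500 nM to 12000 nM. The step that the limit leaves unreadable from compound 3 to compound 4 is the expectation that follows.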

Compound 4, solubility: < 5000 nM
Compound 4 ended at the assay's limit; the forecaster's own chance of this, stated with the estimate: 70%; the middle value does not contradict the limit.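

Compound 4 sits at the limit with compound 1, compound 2 and compound 3, so no step to compound 4 can be read: the limit of < 5000 nM in this assay, at which 4 of the 4 values shown sit.

The compounds shown leave open how these four rank in this assay, and whether any replacement of the group changes the read-out.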